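Lengthening the alkyl chain weakens inhibition

The source may report more compounds than this note shows. Statements on the series, on what has been measured and on what is new or still open speak of the compounds shown alone.

Measured so far, in a functional assay on NALM-6 cells (Homo sapiens); on this read-out lower numbers stand for stronger inhibition and higher numbers for weaker inhibition:
- compound 1 `CCCCCCCCCCCCSC[C@H](NC(C)=O)C(=O)CCl` gives 2000 nM
- compound 2 `CCCCCCCCCCCCCCCSC[C@H](NC(C)=O)C(=O)CCl` gives 8900 nM
- compound 3 `CCCCCCCCCCCCCCCCCCSC[C@H](NC(C)=O)C(=O)CCl` reaches only a limit of the assay, > 100000 nM

Compound 3 thus stands at the weak end of the three: its value is not a number but a limit, as stated in the limit of > 100000 nM in this assay, at which 1 of the 3 values shown sits. Compound 4 `CCCCCCCCCCCCCCCCCCCCCCSC[C@H](NC(C)=O)C(=O)CCl` differs from compound 3 by butyl in place of hydrogen on a saturated chain carbon, ten or more bonds along the chain from a sulfur.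

Among the measured compounds shown here, two measured steps bear on this change. Lengthening the chain gave a 4.5-fold higher number from compound 1 to compound 2 (0.65 log units; beyond the scatter), and lengthening it again gave an at least 11-fold higher number from compound 2 to compound 3 (1.05 log units; beyond the scatter); over both, an at least 50-fold higher number from compound 1 to compound 3 (1.69 log units; beyond the scatter). Each extension of the chain has so far raised the number in this assay, and compound 3 already sits at the limit.

For compound 4 the expectation is therefore a further weakening or, more likely, again only a limit: the estimate is 300000 nM, ranging from 100000 nM to 1000000 nM, which amounts to an expected step that the limit leaves unreadable from compound 3 to compound 4.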

Compound 4, half-maximal inhibitory concentration: > 100000 nM
Compound 4 gave a limit, no number; the forecaster's own chance of this, stated with the estimate: 95%; the middle value is on the limit's open side.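

In this assay compound 4 gives > 100000 nM, which is a limit of the assay and not a number, so the step from compound 3 cannot be read. Set against the shorter chains, the added heptyl gives an at least 11-fold higher number from compound 2 to compound 4 (1.05 log units; beyond the scatter), and the added decyl gives an at least 50-fold higher number from compound 1 to compound 4 (1.69 log units; beyond the scatter); these sizes are bounded by the limit, so the true losses could be larger. The new finding is that adding butyl to this saturated chain carbon brings no readable recovery of inhibition, and the series now has no readable range left at this end: the limit of > 100000 nM in this assay, at which 2 of the 4 values shown sit.

From the compounds shown here alone, whether a chain shorter than that of compound 1, such as octyl, would inhibit more strongly remains open. Also open, going by these compounds, is whether a long chain carrying an amine or a carboxylic acid would bring inhibition back.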